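This account rests on a few compounds, and the source may have more. Where it says the series, first, only, none or still open, it means among the compounds named here.

In a functional assay on PC-3 cells (Homo sapiens) for cytotoxicity, read by WST assay, with a stated time of 3 days (on this read-out lower numbers stand for stronger inhibition and higher numbers for weaker inhibition), compound 1 `Cn1ccnc1/C=C/C(=O)/C=C/c1coc2ccccc2c1=O` gives 2800 nM, compound 2 `CCCCn1ccnc1/C=C/C(=O)/C=C/c1coc2ccccc2c1=O` gives 2000 nM and compound 3 `CCCCCn1ccnc1/C=C/C(=O)/C=C/c1coc2ccccc2c1=O` gives 2100 nM, so compound 3 stands within the scatter of both others. Still unmeasured is compound 4 `CC(C)n1ccnc1/C=C/C(=O)/C=C/c1coc2ccccc2c1=O`, which carries isopropyl in place of pentyl on an aromatic nitrogen. Three measured steps alter the chain on that nitrogen: a 1.4-fold lower number from compound 1 to compound 2 (0.15 log units; within the scatter), a 1.3-fold lower number from compound 1 to compound 3 (0.12 log units; within the scatter) and a 1.1-fold higher number from compound 2 to compound 3 (0.02 log units; within the scatter). All three lie within the scatter, although none of them brings in isopropyl. No step beyond the scatter is therefore expected in this assay. The expected step is a 1.1-fold higher number from compound 3 to compound 4 (0.04 log units; within the scatter). The value of compound 4 is estimated at 2300 nM, with an expected range from 1200 nM to 4200 nM.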

Compound 4, half-maximal inhibitory concentration: 2300 nM
Compound 4: middle estimate and measured number agree at the digits printed; the measured number falls inside the stated range.
By their numbers in this assay, from the lowest: compounds 2, 3, 4 and 1 (each within the scatter of the next).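

In this assay the steps of a 1.1-fold higher number from compound 3 to compound 4 (0.04 log units; within the scatter) and a 1.2-fold higher number from compound 2 to compound 4 (0.06 log units; within the scatter) and a 1.2-fold lower number from compound 1 to compound 4 (0.09 log units; within the scatter) all lie within the scatter. Isopropyl, the only branched chain among these compounds, therefore stands level with the straight chains on this aromatic nitrogen, so branching adds no measurable change to what the straight chains showed. No evidence is available that bears on this result. The compounds shown leave open whether a phenyl ring, or a chain ending in an amine or a carboxylic acid, on this nitrogen would move the number beyond the scatter.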